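A few compounds are considered here, and "the series" means these few. Any claim that something is new, unique, unknown or untested is made for them only; others in the source may bear on it.

In an ADME assay on HEK-293T cells (Homo sapiens) for cytotoxicity, read by MTT assay, with a stated time of 48 h (on this read-out lower numbers stand for higher toxicity in this test and higher numbers for lower toxicity in this test), compound 1 `Cn1cc(C2CC(c3ccccc3)=NN2C(=O)c2ccc(Cl)nc2)c2ccccc21` returned > 300000 nM, which is a limit and not a number. Compound 2 `Cn1cc(C2CC(c3ccc(F)cc3)=NN2C(=O)c2cccnc2)c2cc(Br)ccc21` likewise gave only a limit, > 300000 nM. Among the compounds with values here, compound 2 therefore has no exact position on the scale, and the only other reading, that of compound 1, is a limit as well. Compound 3 `COc1cc(C2=NN(C(=O)c3cccnc3)C(c3cn(C)c4ccc(Br)cc34)C2)cc(OC)c1OC` keeps the core of compound 2 and carries one change: 3,4,5-trimethoxyphenyl in place of 4-fluorophenyl on a carbon with a double bond to nitrogen, with 3,4,5-trimethoxyphenyl in place of 4-fluorophenyl on a carbon with a double bond to nitrogen. Within the data shown here, no step between measured compounds gives a size for such a change. Resting on (the limit of > 300000 nM in this assay, at which 2 of the 2 values shown sit), the step of a number no higher from compound 2 to compound 3 (the limit leaves the size open) is expected to be none beyond the scatter, and any shift that does appear is expected toward lower numbers in this assay. For compound 3 the estimated half-maximal cytotoxic concentration is 300000 nM, with an expected range of 120000 nM to 600000 nM.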

Compound 3, half-maximal cytotoxic concentration: 131000 nM
The estimate for compound 3 lay 2.3-fold (0.36 log units) above the measured number; the range from low to high includes it.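

In this assay, within the data shown here, 3,4,5-trimethoxyphenyl in place of 4-fluorophenyl on the carbon with a double bond to nitrogen brings an at least 2.2-fold lower number from compound 2 to compound 3 (0.35 log units; beyond the scatter), a shift toward higher toxicity, so this position can move the read-out, which the earlier compounds could not show. The reading of compound 2, > 300000 nM, is a limit and not a number. Going by these compounds, the step therefore has a lower bound only, and its full size stays open, with most of the readings stopping at the same ceiling: the limit of > 300000 nM in this assay, at which 2 of the 3 values shown sit.

The compounds shown leave open whether a phenyl ring with a single methoxy group, or with an amine, at this place would also lower the number. They also leave open whether the same change would act alike on a core without the bromine.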